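The source may report more compounds than this note shows. Statements on the series, on what has been measured and on what is new or still open speak of the compounds shown alone.

Compound 1 `O=C(Nc1cccc(-n2cc(-c3ccncc3)c(-c3cc(O)cc(Cl)c3)n2)c1)Nc1ccc(Cl)c(C(F)(F)F)c1` and compound 2 `COc1cc(Cl)cc(-c2nn(-c3cccc(NC(=O)Nc4ccc(Cl)c(C(F)(F)F)c4)c3)cc2-c2ccncc2)c1` share one core and differ only in a methyl in place of hydrogen on an oxygen on an aromatic ring. In a functional assay on IGROV-1 cells (Homo sapiens) for inhibition, read by sulforhodamine B assay, with a stated time of 48 h, tested at 10 uM (a lower number here means a stronger effect, a higher number a weaker effect of the compound at the concentration tested), compound 1 gives 30.6%, and compound 2 gives 30.2%; the step of a number 0.4 percentage points lower from compound 1 to compound 2 (within the scatter) lies within the scatter, so the two numbers cannot be told apart. Compound 2 thus stands among the two numbers without being separable from compound 1. Compound 3 `COc1cc(Cl)cc(-c2nn(-c3cccc(NC(=O)c4cccc(C(F)(F)F)c4)c3)cc2-c2ccncc2)c1` is built from compound 2 by one change: 3-(trifluoromethyl)phenyl in place of (4-chloro-3-(trifluoromethyl)phenyl)amino on a carbonyl carbon. For the measured compounds named here, no measured step touches this part of the molecule; the only measured step concerns the oxygen on the aromatic ring, so nothing measured bears directly on it. Lacking a guide, compound 3 is expected to give a somewhat higher number than compound 2, a step of a number 14.8 percentage points higher from compound 2 to compound 3 (beyond the scatter), with wide uncertainty. The estimate for compound 3 is 45%, within a range from 25% to 70%.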

Compound 3, a percentage reported as activity, at one concentration (the size of the read-out at that concentration, not a potency): 80.7%
The estimate for compound 3 lay 35.7 percentage points below the measured number, outside the stated range (above it).
By their numbers in this assay, from the lowest: compounds 2 and 1 (each within the scatter of the next); then compound 3.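

Unlike the methyl on the oxygen, where a number 0.4 percentage points lower from compound 1 to compound 2 (within the scatter) stays within the scatter, the group on the carbonyl carbon matters greatly: in this assay replacing (4-chloro-3-(trifluoromethyl)phenyl)amino with 3-(trifluoromethyl)phenyl gives a number 50.5 percentage points higher from compound 2 to compound 3 (beyond the scatter) and so a much weaker effect at the concentration tested. This single swap removes the nitrogen with its hydrogen-bond donor and also the chlorine, leaving the trifluoromethyl-bearing ring in place, so the drop cannot be assigned to any one of these parts. No measurement at hand explains the size of this step.

The compounds shown leave open whether the nitrogen or the chlorine carries the effect. Placing (3-(trifluoromethyl)phenyl)amino or 4-chloro-3-(trifluoromethyl)phenyl on the carbonyl carbon would separate the two.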